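Methyl-to-Hydrogen Step in a Kinase Inhibitor Series

The source may report more compounds than this note shows. Statements on the series, on what has been measured and on what is new or still open speak of the compounds shown alone.

Measured compounds in an assay on isolated protein for inhibition of serine/threonine-protein kinase TNNI3K (Homo sapiens); on this read-out higher numbers stand for weaker inhibition and lower numbers for stronger inhibition:
compound 1, `CNc1cc(Oc2ccc(NC(=O)Nc3cccc(C)c3)cc2)ncn1`, gives 1260 nM
compound 2, `CNc1cc(Oc2ccc(NC(=O)Nc3ccccc3)cc2)ncn1`, gives 6300 nM
compound 3, `CNc1cc(Oc2c(C)cc(NC(=O)Nc3cccc(C(F)(F)F)c3)cc2C)ncn1`, gives 25 nM

Compound 3 stands lowest of the three; the difference between its core and the core of compound 1 is not broken down here. Between compound 1 and compound 2 the change is hydrogen in place of methyl on an aromatic carbon, and the measured step is a 5.0-fold higher number from compound 1 to compound 2 (0.70 log units; beyond the scatter).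

Compound 4, `CNc1cc(Oc2ccc(NC(=O)Nc3cccc(C(F)(F)F)c3)cc2C)ncn1`, differs from compound 3 by hydrogen in place of methyl on an aromatic carbon. This is the same kind of change, not the same: in compound 1 the carbon is only meta to a large group, whereas in compound 3 it is ortho to a (6-(methylamino)pyrimidin-4-yl)oxy group and meta to a methyl group as well.

The expected step is a 3.0-fold higher number from compound 3 to compound 4 (0.48 log units; beyond the scatter), set beside a 5.0-fold higher number from compound 1 to compound 2 (0.70 log units; beyond the scatter), resting on that single measured step with the surroundings differing. Compound 4 is expected to give 75 nM in this assay, estimated within 30 nM to 250 nM.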

Compound 4, half-maximal inhibitory concentration: <= 10 nM
Compound 4: only a limit was reported (the forecaster's own chance of this, stated with the estimate: 2%); middle value at least 7.5-fold (0.87 log units) away from the limit.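

In this assay, hydrogen in place of methyl on an aromatic carbon gives an at least 2.5-fold lower number from compound 3 to compound 4 (0.39 log units; beyond the scatter). The change therefore does not carry over in the same direction from the core of compound 1 to the core of compound 3, although only these two cores are compared: the same change on two cores in this assay, a 5.0-fold higher number (0.70 log units; beyond the scatter) from compound 1 to compound 2 and an at least 2.5-fold lower number (0.39 log units; beyond the scatter) from compound 3 to compound 4, at least 12-fold (1.09 log units) apart, beyond the scatter of two such steps. Compound 4 gives <= 10 nM, which is a limit of the assay and not a number, so the full size of the step and the cause of the reversal remain unknown: the limit of <= 10 nM in this assay, at which 1 of the 4 values shown sits.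

Still open, as far as these compounds go, is whether the reversal follows the place of the methyl or the rest of the core. Also open, from the compounds shown here alone, is how an ethyl group, a chlorine or a methoxy group would read at that carbon.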